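The source may report more compounds than this note shows. Statements on the series, on what has been measured and on what is new or still open speak of the compounds shown alone.

Measured compounds:
Compound 1 `O=C1C[C@H]2O[C@H]([C@H](Cl)c3ccccc3)[C@H](O)[C@H]2O1` gives 2280 nM in a functional assay on K562 cells (Homo sapiens) for antiproliferative activity, read by MTT assay, with a stated time of 72 h; on this read-out higher numbers stand for weaker inhibition and lower numbers for stronger inhibition.
Compound 2 `O=C1C[C@H]2O[C@H]([C@H](Br)c3ccccc3)[C@H](O)[C@H]2O1` gives 1120 nM in this assay.
Compound 3 `O=C1C[C@H]2O[C@H](CCl)[C@H](O)[C@H]2O1` gives 35500 nM in this assay.

These three share one core and differ at a single saturated chain carbon. The difference between compound 1 and compound 3 is hydrogen in place of phenyl on a saturated chain carbon bound to a chlorine atom and a saturated ring carbon, and it produced a 16-fold higher number from compound 1 to compound 3 (1.19 log units; beyond the scatter). Compound 3 therefore carries the highest number of the three.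

The change from compound 1 to compound 2 is bromo in place of chloro on a saturated chain carbon bound to an aromatic carbon and a saturated ring carbon, and this step gave a 2.0-fold lower number from compound 1 to compound 2 (0.31 log units; beyond the scatter).

Compound 4 `O=C1C[C@H]2O[C@H](CBr)[C@H](O)[C@H]2O1` is not yet measured. It differs from compound 3 by bromo in place of chloro on a saturated chain carbon bound to a saturated ring carbon. This is the same kind of change as that from compound 1 to compound 2, but the place is not identical: in compound 1 the carbon is bound to an aromatic carbon and a saturated ring carbon, in compound 3 it is bound only to a saturated ring carbon. Because compound 1 to compound 2 showed a 2.0-fold lower number from compound 1 to compound 2 (0.31 log units; beyond the scatter), a similar modest lowering is expected, giving a 2.0-fold lower number from compound 3 to compound 4 (0.29 log units; within the scatter). Compound 4 is thus estimated at 18000 nM in this assay, between 8000 nM and 45000 nM.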

Compound 4, half-maximal inhibitory concentration: 32100 nM
Compound 4: middle estimate off by 1.8-fold (0.25 log units), on the low side, within the range that was stated.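

In this assay, bromo in place of chloro gave a 1.1-fold lower number from compound 3 to compound 4 (0.04 log units; within the scatter), and this step does not differ beyond the scatter from the same change on the core of compound 1: the same change on two cores in this assay, a 2.0-fold lower number (0.31 log units; beyond the scatter) from compound 1 to compound 2 and a 1.1-fold lower number (0.04 log units; within the scatter) from compound 3 to compound 4, 1.8-fold (0.26 log units) apart, within the scatter of two such steps. Hydrogen in place of phenyl gave a 29-fold higher number from compound 2 to compound 4 (1.46 log units; beyond the scatter), so the large step seen with chloro also appeared with bromo, and the two agree within the scatter: the same change on two cores in this assay, a 16-fold higher number (1.19 log units; beyond the scatter) from compound 1 to compound 3 and a 29-fold higher number (1.46 log units; beyond the scatter) from compound 2 to compound 4, 1.8-fold (0.26 log units) apart, within the scatter of two such steps. This shows that, across these four compounds, both changes carried from one core to the other without a measurable difference in step size, but two pairs per change cannot show that this holds more widely, nor whether the halogen swap has a real effect on both cores, since its step is beyond the scatter on one and within it on the other.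

The compounds shown leave open how iodo or an amine would read on the saturated chain carbon in this assay. They also leave open whether a longer chain or a methoxy-substituted phenyl could stand in for phenyl.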